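Furan-2-yl to Thiophen-3-yl on the Chain Carbon

The compounds below may be only part of what the source reports. "The series", "measured", "known", "first", "only" and "open" are said of these compounds alone.

Measured compounds:
compound 1, `COc1ccc(NCc2ccccc2)cc1`, which in a functional assay on L929 cells (Mus musculus) for inhibition, read by MTT assay, with a stated time of 5 days (on this read-out higher numbers stand for weaker inhibition and lower numbers for stronger inhibition), gives 30 ug/mL;
compound 2, `O=[N+]([O-])c1cc(O)ccc1NCc1ccccc1`, which in this assay gives 9 ug/mL;
compound 3, `COc1ccc(NC(C)c2ccco2)cc1`, which in this assay gives 40 ug/mL.

Compound 3 carries the highest number of the three, yet compound 1 sits within the usual scatter of it, so the two cannot be ranked; only compound 2 lies beyond the scatter, with the lower number. Compound 4, `COc1ccc(NC(C)c2ccsc2)cc1`, differs from compound 3 by thiophen-3-yl in place of furan-2-yl on a saturated chain carbon bound to a nitrogen on an aromatic ring and a saturated chain carbon. Within the data shown here, no pair of measured compounds shows this exchange, so nothing here tells how large such a step is. The expected step of a 1.1-fold lower number from compound 3 to compound 4 (0.06 log units; within the scatter) is therefore none beyond the scatter. For compound 4 the estimate is 35 ug/mL, with a range from 15 ug/mL to 90 ug/mL.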

Compound 4, half-maximal inhibitory concentration: 30 ug/mL
Beside the measured number, compound 4's estimate is 1.2-fold (0.07 log units) above it; the range from low to high includes it.
By their numbers in this assay, from the lowest: compound 2; then compounds 1, 4 and 3 (each within the scatter of the next).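

In this assay, among these compounds, thiophen-3-yl in place of furan-2-yl gives a 1.3-fold lower number from compound 3 to compound 4 (0.12 log units; within the scatter) as the first reading of this exchange. On a saturated chain carbon bound to a nitrogen on an aromatic ring and a saturated chain carbon, the two five-membered aromatic rings therefore cannot be told apart on this read-out. No measured property bears on this result, so it remains without an explanation here.

The compounds shown leave open whether an amine or a carboxylic acid on the thiophen-3-yl ring would move the number beyond the scatter. They also leave open whether a longer chain on that same carbon would do so.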